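This account rests on a few compounds, and the source may have more. Where it says the series, first, only, none or still open, it means among the compounds named here.

Compound 2 `NCCCC[C@H](NC(=O)CN(c1nc(Cl)nc2[nH]cnc12)C1CC1)C(=O)OCc1ccccc1` gives 16.8% in a functional assay on the whole organism (Tail, strain ICR) with Mus musculus as the target, in the tail flick test, with a stated time of 120 min, at a dose of 25 umol/kg by the oral route; on this read-out higher numbers stand for a stronger effect at the one dose given and lower numbers for a weaker effect. Its nearest neighbour among the measured compounds is compound 1 `O=C(CN(c1nc(Cl)nc2[nH]cnc12)C1CC1)N[C@@H](CC(=O)OCc1ccccc1)C(=O)OCc1ccccc1`, which gives 12.1% in this assay, and the two numbers differ only within the scatter. Compound 3 `CSCC[C@H](NC(=O)CN(c1nc(Cl)nc2[nH]cnc12)C1CC1)C(=O)OCc1ccccc1` has not yet been measured in this assay. It differs from compound 2 in one place: methylsulfanyl in place of 2-aminoethyl on a saturated chain carbon, three bonds along the chain from an amide-type nitrogen and a carbonyl carbon. For the measured compounds named here, the only step measured so far that touches this part of the molecule is a number 4.7 percentage points higher from compound 1 to compound 2 (within the scatter), which also altered the side chain and did not move the read-out beyond the scatter. Going by the values given here, that single step is the sole guide here, and it suggests that replacing the chain with methylsulfanyl is expected to leave the effect about where it is, with a step of a number 1.8 percentage points lower from compound 2 to compound 3 (within the scatter). Compound 3 is therefore estimated at 15%, with a likely range from 5% to 28%.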

Compound 3, a percentage reported as activity, at one dose (the size of the read-out at that dose, not a potency): 31.6%
Beside the measured number, compound 3's estimate is 16.6 percentage points below it; the measured number lies above the stated range.
By their numbers in this assay, from the lowest: compounds 1 and 2 (each within the scatter of the next); then compound 3.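

In this assay, the side chain at this position now shows that it can change the effect at the one dose given: methylsulfanyl in place of 2-aminoethyl gives a number 14.8 percentage points higher from compound 2 to compound 3 (beyond the scatter) on the same core. The wider swap of benzyloxycarbonyl for (methylsulfanyl)methyl points the same way, with a number 19.5 percentage points higher from compound 1 to compound 3 (beyond the scatter), whereas the earlier pair of compounds had shown no step beyond the scatter. Nothing available accounts for this gain in effect.

Still open, going by these compounds, is whether the sulfur atom itself matters, which a methoxy group in place of methylsulfanyl, or a plain butyl chain, could test. A carboxylic acid on this side chain, or a longer chain carrying the sulfur, would show how far the gain extends.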